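Swapping an acid for a guanidine-like group on a shared core

The source may hold more compounds than are shown below. What is called first, only, known or untested is meant among the compounds shown, and "the series" means these compounds.

Of the compounds shown here, three built on one core have been tested in a functional assay on the whole organism (Tail, strain ICR) with Mus musculus as the target, in the tail flick test, with a stated time of 90 min, at a dose of 25 umol/kg by the oral route; on this read-out higher numbers stand for a stronger effect at the one dose given and lower numbers for a weaker effect. Compound 1 `O=C(OCc1ccccc1)[C@@H]1CCCN1C(=O)CN(c1nc(Cl)nc2[nH]cnc12)C1CC1` gives 43.3%. Compound 2 `NCCCC[C@H](NC(=O)CN(c1nc(Cl)nc2[nH]cnc12)C1CC1)C(=O)OCc1ccccc1` gives 35.3%. Compound 3 `O=C(O)CC[C@H](NC(=O)CN(c1nc(Cl)nc2[nH]cnc12)C1CC1)C(=O)O` gives 44.7%. Among the measured compounds shown here, the three numbers sit close together: the gap from compound 3 to compound 1 and the gap from compound 3 to compound 2 both lie within the usual scatter of such measurements, so no compound can be set apart from the others on these figures.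

Compound 4 `N=C(N)NCCC[C@H](NC(=O)CN(c1nc(Cl)nc2[nH]cnc12)C1CC1)C(=O)O` has not yet been measured. It differs from compound 3 in one place: a group of 5 heavy atoms (2 carbon, 3 nitrogen; no ring) in place of a group of 3 heavy atoms (1 carbon, 2 oxygen; no ring), on a saturated chain carbon, three bonds along the chain from an amide-type nitrogen and a carbonyl carbon. The new group sits on a saturated chain carbon, three bonds along the chain from an amide-type nitrogen and a carbonyl carbon.

For the measured compounds named here, no measured pair shows the effect of this exact change, so nothing in the numbers points one way or the other. Compound 4 is therefore expected to stay near compound 3, with a step from compound 3 to compound 4 of about a number 2.7 percentage points lower from compound 3 to compound 4 (within the scatter), which is within the scatter. Compound 4 is estimated at 42% in this assay, with a likely range from 24% to 60%.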

Compound 4, a percentage reported as activity, at one dose (the size of the read-out at that dose, not a potency): 27.6%
Beside the measured number, compound 4's estimate is 14.4 percentage points above it; low and high end bracket the measured number.
By their numbers in this assay, from the lowest: compounds 4, 2, 1 and 3 (each within the scatter of the next, the first and the last beyond it).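

In this assay, among the compounds shown here, this is the first step in the set that can be read as a real difference: putting the group of 5 heavy atoms (2 carbon, 3 nitrogen) in place of the carboxy group gives a number 17.1 percentage points lower from compound 3 to compound 4 (beyond the scatter). The site, a saturated chain carbon three bonds along the chain from an amide-type nitrogen and a carbonyl carbon, is therefore not indifferent to what it carries, at least at this one dose and time. No separate measurement here accounts for the drop.

Going by these compounds, whether a urea or a hydroxyl group at this site would stay close to compound 3 or fall towards compound 4 remains open. On these data alone, whether the step would hold at other doses also remains open, since a single-dose read-out shows the size of an effect, not a potency.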